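Swapping the Aromatic Ring on the Amide Arm

A few compounds are considered here, and "the series" means these few. Any claim that something is new, unique, unknown or untested is made for them only; others in the source may bear on it.

Compound 1 `COc1ccc(CNC(=O)c2nc(-c3ccc(F)cc3)n(CC[C@@H](O)C[C@@H](O)CC(=O)O)c2C2CC2)cc1F`: 3.7 nM
Compound 2 `O=C(O)C[C@H](O)C[C@H](O)CCn1c(-c2ccc(F)cc2)nc(C(=O)NCc2cccc(F)c2)c1C1CC1`: 1.2 nM

Among the compounds with values here, in an assay on microsomes from liver for inhibition of 3-hydroxy-3-methylglutaryl-coenzyme A reductase (Rattus norvegicus), read by scintillation counting, with stated times of 0.5 h and 0.75 h (a higher number here means a weaker inhibitor, a lower number a stronger inhibitor), compound 1 gives 3.7 nM, the higher of the two numbers measured so far. Within the data shown here, compound 2 gives 1.2 nM, and the only step measured is a 3.1-fold lower number from compound 1 to compound 2 (0.49 log units; beyond the scatter). Compound 3 `Cc1cccc(CNC(=O)c2nc(-c3ccc(F)cc3)n(CC[C@@H](O)C[C@@H](O)CC(=O)O)c2C2CC2)c1` is not yet measured. Compared with compound 1 it carries 3-methylphenyl in place of 3-fluoro-4-methoxyphenyl on a saturated chain carbon bound to an amide-type nitrogen. This removes the same methoxy group that was lost in the step from compound 1 to compound 2, and in addition exchanges fluorine for a methyl group on the same ring. Among the measured compounds shown here, no measured pair shows what that second exchange does on its own, so the expectation rests on the methoxy removal alone. The number for compound 3 is therefore expected to fall by about a 2.3-fold lower number from compound 1 to compound 3 (0.36 log units; beyond the scatter), a modest change, with the methyl-for-fluorine part left uncertain. Compound 3 is estimated at 1.6 nM, within 0.6 nM to 4.5 nM.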

Compound 3, half-maximal inhibitory concentration: 7.2 nM
Estimate against measurement, compound 3: 4.5-fold (0.65 log units) below; the measured number lies above the stated range.
By their numbers in this assay, from the lowest: compound 2; then compounds 1 and 3 (each within the scatter of the next).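

Within the data shown here, this result gives the first single exchange at the fluorine-bearing ring carbon: in this assay methyl in place of fluoro is a 6.0-fold higher number from compound 2 to compound 3 (0.78 log units; beyond the scatter) and so outweighs the scatter. Losing the methoxy group alone had given a lower number, but the full change from 3-fluoro-4-methoxyphenyl to 3-methylphenyl reads a 1.9-fold higher number from compound 1 to compound 3 (0.29 log units; within the scatter) and leaves compound 1 and compound 3 not separable by this measurement. Nothing given here explains why fluoro and methyl part in this way.

A ring carrying both methyl and methoxy would show whether the methoxy group counts the same way once fluorine is gone. Chlorine or trifluoromethyl in place of the fluorine of compound 2 would show whether the number stays near that of compound 2 or moves toward that of compound 3.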